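The source may hold more compounds than are shown below. What is called first, only, known or untested is meant among the compounds shown, and "the series" means these compounds.

Measured compounds:
compound 1, `COc1ccc(C(=O)/C=C/c2cc3ccccc3[nH]c2=O)cc1` — 55800 nM
compound 2, `O=C(/C=C/c1cc2ccccc2[nH]c1=O)c1ccc(O)cc1` — 11800 nM

Among the two compounds measured in a functional assay on TK-10 cells (Homo sapiens) for cytotoxicity, read by sulforhodamine B assay, with a stated time of 24 h (a higher number here means a weaker inhibitor of growth, a lower number a stronger inhibitor of growth), compound 2 stands with the lowest number; the only other compound, compound 1, gives 55800 nM, a step of a 4.7-fold lower number from compound 1 to compound 2 (0.67 log units; beyond the scatter), which exchanges a methyl for a hydrogen on an oxygen on an aromatic ring.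

Compound 3, `O=C(/C=C/c1cc2ccccc2[nH]c1=O)c1ccc(Cl)cc1`, carries the change (chloro in place of hydroxy on an aromatic carbon), that is, chloro in place of hydroxy on an aromatic carbon of the six-membered carbon-only ring, para to a large group. Among the compounds with values here, no measured step touches this exchange: the one step on record, a 4.7-fold lower number from compound 1 to compound 2 (0.67 log units; beyond the scatter), alters the same position but only trades methyl for hydrogen on the oxygen, and neither compound measured so far lacks an oxygen at this place. The data give no direction for removing that oxygen altogether. The expectation for compound 3 is therefore held close to compound 2, widened both ways, with a step of a 1.7-fold higher number from compound 2 to compound 3 (0.23 log units; within the scatter) expected. Compound 3 is estimated at 20000 nM, within a range of 6000 nM to 70000 nM.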

Compound 3, concentration for total growth inhibition: 20800 nM
For compound 3 the middle estimate is 1.0-fold (0.02 log units) below the measured one, and the stated range covers the measured number.
By their numbers in this assay, from the lowest: compounds 2 and 3 (each within the scatter of the next); then compound 1.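

Compound 3 shows that an oxygen is not needed at this place to keep the number near that of compound 2: in this assay the exchange of hydroxy for chloro gives a 1.8-fold higher number from compound 2 to compound 3 (0.25 log units; within the scatter) and so leaves 4-hydroxyphenyl and 4-chlorophenyl unresolved, although the hydrogen-bond donor and acceptor of hydroxy leave with it. The earlier step could have been read as a need for the hydrogen on that oxygen, but compound 3 goes against this reading, since it has no such hydrogen and still shows a 2.7-fold lower number from compound 1 to compound 3 (0.43 log units; beyond the scatter) in this modest step. Among the three groups at this place, methoxy in compound 1 therefore stands apart with the highest number, while hydroxy and chloro stay together, and nothing available explains this difference.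

The compounds shown leave open whether an amine, a carboxylic acid or a longer alkoxy chain such as ethoxy at this place would stay with compound 2 and compound 3 or fall with compound 1. They also leave open how a methyl in place of the amide hydrogen of the shared core would read in this assay against these three groups.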